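The compounds below may be only part of what the source reports. "The series", "measured", "known", "first", "only" and "open" are said of these compounds alone.

Compound 1, `O=C(Nc1ccccc1)Nc1ccc(OC(=O)c2ccccc2)cc1`: 123000 nM
Compound 2, `O=C(Nc1ccccc1)Nc1ccc(OC(=O)c2ccc(F)cc2)cc1`: 128000 nM
Compound 3, `Cc1ccc(C(=O)Oc2ccc(NC(=O)Nc3ccccc3)cc2)cc1`: 19900 nM

These three compounds share one core and differ only in a single group on one aromatic ring. All were tested in a functional assay on HT-29 cells (Homo sapiens) for antiproliferative activity, read by MTT assay, with a stated time of 48 h; a higher number here means a weaker inhibitor, a lower number a stronger inhibitor. Compound 1 carries a hydrogen at the place in question, compound 2 a fluoro and compound 3 a methyl. The step of a 1.0-fold higher number from compound 1 to compound 2 (0.02 log units; within the scatter) shows that fluoro in place of hydrogen changed nothing that can be told apart from the scatter. The steps of a 6.2-fold lower number from compound 1 to compound 3 (0.79 log units; beyond the scatter) and a 6.4-fold lower number from compound 2 to compound 3 (0.81 log units; beyond the scatter) show that the methyl brought a modest gain, and compound 3 stands with the lowest number of the three, beyond the scatter from both others.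

Compound 4, `COc1ccc(C(=O)Oc2ccc(NC(=O)Nc3ccccc3)cc2)cc1`, has not yet been measured. It differs from compound 3 in one place: methoxy in place of methyl on an aromatic carbon. Only the two steps leading to compound 3 bear on this change. In them a group at this place moved the number, while the fluoro of compound 2 did not. Going by the values given here, a methoxy has no direct precedent here, so the expectation is loose. Compound 4 is estimated at 32000 nM, with a range from 9000 nM to 120000 nM, which means an expected step of a 1.6-fold higher number from compound 3 to compound 4 (0.21 log units; within the scatter), a modest weakening or no change beyond the scatter.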

Compound 4, half-maximal inhibitory concentration: 175000 nM
For compound 4 the middle estimate is 5.5-fold (0.74 log units) below the measured one; the measured number lies above the stated range.
By their numbers in this assay, from the lowest: compound 3; then compounds 1, 2 and 4 (each within the scatter of the next).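

In this assay, the gain seen with the methyl does not extend to the next group tried at this place, since an 8.8-fold higher number from compound 3 to compound 4 (0.94 log units; beyond the scatter) removes it. The methoxy differs from the methyl only by one added oxygen, yet the result falls in with the hydrogen and the fluoro, as a 1.4-fold higher number from compound 1 to compound 4 (0.15 log units; within the scatter) and a 1.4-fold higher number from compound 2 to compound 4 (0.14 log units; within the scatter) show, so among these four compounds the methyl alone stands apart, and a small edit to that group is enough to lose its gain. The data shown offer no measurement that explains why the methyl differs from the other three groups.

Going by these compounds alone, with only one group giving a gain, it remains open whether that gain is particular to the methyl or would also appear with an ethyl, a chloro or a trifluoromethyl on the same aromatic carbon. Going by these compounds, it is also open how an amine, a hydroxyl or a carboxylic acid would behave at this place, and whether the same changes would give the same pattern on the other aromatic ring of the shared core.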